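Trifluoromethoxy for Trifluoromethyl: an Expected Limit

The source may report more compounds than this note shows. Statements on the series, on what has been measured and on what is new or still open speak of the compounds shown alone.

Three compounds on a shared core have each been tested in an ADME assay on HepG2 cells (Homo sapiens) for cytotoxicity, read by resazurin assay, with a stated time of 24 h; on this read-out higher numbers stand for weaker inhibition and lower numbers for stronger inhibition. Compound 1 `COc1ccc2c(=O)c(-c3ccc(Oc4ccc(OC(F)(F)F)cc4)cc3)c(C)[nH]c2c1` gives only a limit of the assay, > 10000 nM. Compound 2 `COc1cc2[nH]c(C)c(-c3ccc(Oc4ccc(OC(F)(F)F)c(F)c4)cc3)c(=O)c2cc1Cl` likewise returns a limit, > 10000 nM. Compound 3 `COc1cc2[nH]c(C)c(-c3ccc(Oc4ccc(C(F)(F)F)cc4)cc3)c(=O)c2cc1Cl` also reaches only a limit, > 10000 nM. Within the data shown here, no step between measured compounds can be drawn, so compound 3 stands where all three stand, at the limit of > 10000 nM in this assay, at which 3 of the 3 values shown sit. Compound 4 `COc1cc2[nH]c(C)c(-c3ccc(Oc4ccc(OC(F)(F)F)cc4)cc3)c(=O)c2cc1Cl` has not yet been measured in this assay; it differs from compound 3 by trifluoromethoxy in place of trifluoromethyl on an aromatic carbon. The step that the limit leaves unreadable from compound 3 to compound 4 is expected to be none beyond the scatter, because compound 3 sits at the limit of > 10000 nM in this assay, at which 3 of the 3 values shown sit. Compound 4 is therefore estimated at 15000 nM, in the range 7000 nM to 50000 nM, and most likely reported again only as a limit.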

Compound 4, half-maximal inhibitory concentration: > 10000 nM
Compound 4: only a limit was reported; the forecaster's own chance of this, stated with the estimate: 85%; the middle value is on the limit's open side.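

Among these compounds, compound 4 reaches only a limit, as do compound 1, compound 2 and compound 3, and no step from any of these to compound 4 can be read. The compounds shown leave open whether any of these changes on the shared core alters the read-out in this assay at all.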